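Swapping Nitro for Trichloromethyl on a Thiocarbamate Scaffold

This account rests on a few compounds, and the source may have more. Where it says the series, first, only, none or still open, it means among the compounds named here.

Compound 1, `CC(=O)Nc1ccc(OC(=S)Nc2ccc(Sc3ccc(C(F)(F)F)cc3)cc2)cc1`, gives 5.96.
Compound 2, `O=[N+]([O-])c1ccc(Sc2ccc(NC(=S)Oc3ccc(O)cc3)cc2)cc1`, gives 5.25.
Compound 3, `O=[N+]([O-])c1ccc(Oc2ccc(NC(=S)Oc3ccc(O)cc3)cc2)cc1`, gives 5.01.

These three values come from a physicochemical assay for lipophilicity; a lower number here means a more polar compound, a higher number a more lipophilic compound. Compound 2 sits between the other two: its gap to compound 3 is within the usual scatter of repeated measurements, so the two cannot be told apart, while compound 1 lies higher by a margin that is beyond the scatter.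

The new compound 4, `Oc1ccc(OC(=S)Nc2ccc(Sc3ccc(C(Cl)(Cl)Cl)cc3)cc2)cc1`, is not yet measured in this assay. It differs from compound 2 in one place: trichloromethyl in place of nitro on an aromatic carbon. Within the data shown here, no pair of measured compounds shows this exact change, so its effect has to be estimated from the groups involved rather than read off a measured step. Replacing a nitro group, which carries two hydrogen-bond acceptors, with a trichloromethyl group, which carries none, is expected to raise the partition coefficient in this assay by a step clearly beyond the scatter.

Compound 4 is therefore estimated at 6.4, with a range from 5.9 to 6.9. That estimate means an expected step of a number 1.15 log units higher from compound 2 to compound 4 (beyond the scatter).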

Compound 4, partition coefficient: 7.43
Compound 4: the middle estimate sits 1.03 log units below what was measured; measured number above the stated range.
By their numbers in this assay, from the lowest: compounds 3 and 2 (each within the scatter of the next); then compound 1; then compound 4.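

Among these compounds, until now, no measured pair differed in one place only, so nothing showed how far a single exchange could move the read-out. In this assay, trichloromethyl in place of nitro on an aromatic carbon, para to a large group, gives a number 2.18 log units higher from compound 2 to compound 4 (beyond the scatter), a large step that shows this position alone can shift the number well beyond the scatter. The exchange changes the heavy atoms and removes the hydrogen-bond acceptors of nitro together, and no measurement shown here separates these differences or accounts for the size of the step.

On these data alone, how a methyl group, an amine or a carboxylic acid on this same aromatic carbon would compare with nitro and trichloromethyl remains open, so a single step cannot yet show a trend across groups at this position. As far as these compounds go, it is also open whether the same exchange made on compound 3 would produce a step of similar size, or whether this one depends on the rest of compound 2.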